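The compounds below may be only part of what the source reports. "The series", "measured", "known", "first", "only" and "open" are said of these compounds alone.

Measured in an ADME assay on Vero 76 cells (Chlorocebus sabaeus) for cytotoxicity, read by MTT assay, with a stated time of 96 h; on this read-out lower numbers stand for higher toxicity in this test and higher numbers for lower toxicity in this test:
- compound 1 `Cc1ccc(C2CC(c3ccccc3)=NN2c2ccc(S(N)(=O)=O)cc2)cc1`: 20000 nM
- compound 2 `NS(=O)(=O)c1ccc(N2N=C(c3ccc(OCc4ccccc4)cc3)CC2c2ccc(Cl)cc2)cc1`: 82000 nM
- compound 3 `Cc1ccc(C2CC(c3ccc(OCc4ccccc4)cc3)=NN2c2ccc(S(N)(=O)=O)cc2)cc1`: 100000 nM

Compound 3 shares the top of this small range with compound 2, with a 1.2-fold higher number from compound 2 to compound 3 (0.09 log units; within the scatter), and stands clear of compound 1, with a 5.0-fold higher number from compound 1 to compound 3 (0.70 log units; beyond the scatter). Compound 4 `Cc1ccc(C2CC(c3ccc(Oc4ccccc4)cc3)=NN2c2ccc(S(N)(=O)=O)cc2)cc1` has phenyl in place of benzyl on an oxygen on an aromatic ring. The step from compound 1 to compound 3 is the only one touching this substituent, and it was modest. The methyl-for-chloro step concerns another group and does not bear on the change. The change only trims the benzyloxy to phenoxy, so no shift beyond the scatter is expected in this assay, and the estimated step is a 1.3-fold lower number from compound 3 to compound 4 (0.12 log units; within the scatter). For compound 4 the estimated value is 75000 nM, with an expected range of 30000 nM to 130000 nM.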

Compound 4, half-maximal cytotoxic concentration: 86000 nM
Compound 4: the middle estimate sits 1.1-fold (0.06 log units) below what was measured; low and high end bracket the measured number.
By their numbers in this assay, from the lowest: compound 1; then compounds 2, 4 and 3 (each within the scatter of the next).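

In the working series, trimming benzyloxy to phenoxy (a 1.2-fold lower number from compound 3 to compound 4 (0.07 log units; within the scatter)) leaves the number in this assay unmoved within the scatter, so benzyl and phenyl on this oxygen are not told apart here. Phenoxy in place of hydrogen (a 4.3-fold higher number from compound 1 to compound 4 (0.63 log units; beyond the scatter)) shows that the rise seen with benzyloxy is not confined to that one group. No data on hand give a reason for either step.

On these data alone, whether an amine or a carboxylic acid at this place would keep the number as high remains open. So does the effect of a longer chain on the oxygen.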